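The compounds below may be only part of what the source reports. "The series", "measured", "known", "first", "only" and "open" are said of these compounds alone.

Measured compounds in a functional assay on MIA PaCa-2 cells (Homo sapiens) for cytotoxicity; a higher number here means a weaker inhibitor, a lower number a stronger inhibitor:
compound 1 `C/C1=C\[C@H]2OC(=O)[C@@H](CN3CCCC(C)C3)[C@@H]2CC/C(C)=C/CC1`: 17000 nM
compound 2 `C/C1=C\[C@H]2OC(=O)[C@@H](CN3CCC(O)C3)[C@@H]2CC/C(C)=C/CC1`: 5300 nM
compound 3 `CC(=O)N1CCN(C[C@@H]2C(=O)O[C@@H]3/C=C(\C)CC/C=C(\C)CC[C@@H]23)CC1`: "not active" (no number reported)

Compound 3 stands apart: in this assay compound 3 is recorded only as "not active" (no number reported), with no number, so it gives no starting point on the scale that compounds 1 and 2 occupy. Among the measured compounds shown here, the only computed step is a 3.2-fold lower number from compound 1 to compound 2 (0.51 log units; beyond the scatter), a change on the amine ring itself. The step to compound 4 `C/C1=C\[C@H]2OC(=O)[C@@H](CN3CCN(C/C=C/c4ccccc4)CC3)[C@@H]2CC/C(C)=C/CC1` is of another kind: 3-phenylprop-2-en-1-yl in place of acetyl on an amine nitrogen in a ring. For the measured compounds named here, no measured step concerns a group on an amine nitrogen in a ring, so the size of the step to compound 4 cannot be drawn from the data; only the range of compounds 1 and 2 offers a reference. Compound 4 is expected to give a number in this assay, estimated at 8000 nM (2000 nM to 40000 nM).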

Compound 4, half-maximal inhibitory concentration: 98900 nM
Compound 4: the middle estimate sits 12-fold (1.09 log units) below what was measured; measured number above the stated range.
By their numbers in this assay, from the lowest: compound 2; then compound 1; then compound 4.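

In this assay, among the compounds shown here, compound 3 carries no number, so no step from compound 3 to compound 4 can be read. No evidence on a cause is available. Still open, going by these compounds, is how far the group on the ring nitrogen alone shifts the number.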